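Fluoro in place of methyl on the biaryl ring

A few compounds are considered here, and "the series" means these few. Any claim that something is new, unique, unknown or untested is made for them only; others in the source may bear on it.

Compound 1: `C[C@H](c1ccc(-c2ccccc2-c2nc(=O)o[nH]2)cc1)N(CC1CC1)c1nc2c(C(=O)O)cccc2o1` gives 60% in an ADME assay on the whole organism (Macaca fascicularis) for pharmacokinetics, read by LC-MS, using cassette dosing; on this read-out lower numbers stand for lower oral bioavailability and higher numbers for higher oral bioavailability
Compound 2: `Cc1ccc(-c2nc(=O)o[nH]2)c(-c2ccc([C@@H](C)N(CC3CC3)c3nc4c(C(=O)O)cccc4o3)cc2)c1` gives 58% in this assay

Within the data shown here, compound 2 stands lowest of the two numbers so far, though its gap to compound 1, a number 2 percentage points lower from compound 1 to compound 2 (within the scatter), lies within the scatter, so the two cannot be ordered. Compound 3, `C[C@H](c1ccc(-c2cc(F)ccc2-c2nc(=O)o[nH]2)cc1)N(CC1CC1)c1nc2c(C(=O)O)cccc2o1`, has not yet been measured. It differs from compound 2 by fluoro in place of methyl on an aromatic carbon. Among the measured compounds shown here, the only measured step that bears on this position is the one from hydrogen to methyl, a number 2 percentage points lower from compound 1 to compound 2 (within the scatter), which was within the scatter. A second small group at the same place is therefore expected to leave oral bioavailability where it is, and the step of no change at the digits printed from compound 2 to compound 3 (within the scatter) is estimated to stay within the scatter. Compound 3 is expected to give 58%, with a range from 44% to 70%.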

Compound 3, oral bioavailability: 82%
For compound 3 the middle estimate is 24 percentage points below the measured one; the measured number lies above the stated range.
By their numbers in this assay, from the lowest: compounds 2 and 1 (each within the scatter of the next); then compound 3.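

At this place, on an aromatic carbon meta to a large group and para to a group of 6 heavy atoms, this assay does respond to the group that sits there: fluoro in place of methyl brings a number 24 percentage points higher from compound 2 to compound 3 (beyond the scatter) and fluoro in place of hydrogen brings a number 22 percentage points higher from compound 1 to compound 3 (beyond the scatter) on the same carbon. Compound 1 and compound 2 alone could have suggested that the position tolerates any small change, yet methyl and fluoro, each of 1 heavy atom, are not interchangeable here. Nothing available explains the difference.

The compounds shown leave open whether this rise belongs to fluoro alone or would also come with chloro or a nitrile at this place. They also leave open whether fluoro on another carbon of this ring would behave the same way.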